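Chloro to cyano on the pyridine-side ring of compound 1

This account rests on a few compounds, and the source may have more. Where it says the series, first, only, none or still open, it means among the compounds named here.

Compound 1 `Cc1ccccc1C(=O)Nc1cc(Cl)ccn1` is the point of departure. In an ADME assay (liver) for metabolic stability, with Liver microsome (Homo sapiens) as the target, read by LC-MS, using microsomes, with a stated time of 60 min, tested at 1 uM (a lower number here means slower removal, a higher number faster removal of the compound), compound 1 gives 128 uL/min, the second highest of the three numbers measured. Compound 2 `Cc1c(F)cccc1C(=O)Nc1cc(Cl)ccn1` gives 254 uL/min in this assay, and the step of a 2.0-fold higher number from compound 1 to compound 2 (0.30 log units; within the scatter) lies within the scatter. For the measured compounds named here, compound 3 `COc1ccc(NC(=O)c2ccccc2C)nc1` gives 23 uL/min, a number well below that of compound 1, and this gap is beyond the scatter; no single-point step connects these two compounds, so only the two values themselves can be compared.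

Compound 4 `Cc1ccccc1C(=O)Nc1cc(C#N)ccn1` differs from compound 1 as follows: cyano in place of chloro on an aromatic carbon. Going by the values given here, none of the measured steps involves a cyano in place of chloro on an aromatic carbon; the only measured step, fluoro in place of hydrogen on an aromatic carbon, was within the scatter and concerns a different ring. Among the compounds with values here, with no step bearing on this change, no direction can be read from the series, and a number close to that of compound 1 is expected, the step being estimated as a 1.3-fold lower number from compound 1 to compound 4 (0.11 log units; within the scatter). Compound 4 is therefore estimated at 100 uL/min in this assay, with a range from 40 uL/min to 260 uL/min.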

Compound 4, intrinsic clearance in a liver preparation (reported as CLH), per the amount of preparation that the assay uses: 82 uL/min
Beside the measured number, compound 4's estimate is 1.2-fold (0.09 log units) above it; the measured number falls inside the stated range.
By their numbers in this assay, from the lowest: compound 3; then compounds 4, 1 and 2 (each within the scatter of the next, the first and the last beyond it).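

Cyano in place of chloro is the first change shown at this position, opposite the ring nitrogen, and in this assay it gives a 1.6-fold lower number from compound 1 to compound 4 (0.19 log units; within the scatter) and so stays inside the scatter. At this position, then, chloro can give way to a nitrile, with one more heavy atom and one hydrogen-bond acceptor, without a step beyond the scatter; on this single pair, chloro is not shown to be required for a number in this range. No measurement at hand accounts for the size of this step.

Open, on these data alone, is whether an amine or a carboxylic acid at this position would also stay within the scatter of compound 1. Also open, as far as these compounds go, is whether the same cyano change would give a comparable step in compound 2, which carries the fluoro group.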